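The compounds below may be only part of what the source reports. "The series", "measured", "known", "first", "only" and "open" are said of these compounds alone.

Measured in a functional assay on L1210 cells (Mus musculus), read by MTT assay; on this read-out lower numbers stand for stronger inhibition and higher numbers for weaker inhibition:
- compound 1 `Nc1ccn([C@@H]2O[C@H](CO)[C@](O)(C3CC3)[C@H]2O)c(=O)n1`: > 350000 nM (a limit)
- compound 2 `C#CC[C@@]1(O)[C@@H](CO)O[C@@H](n2ccc(N)nc2=O)[C@@H]1O`: > 350000 nM (a limit)

Compound 2 gives only a limit in this assay, not a number, at > 350000 nM. Both measured compounds sit at the limit of > 350000 nM in this assay, at which 2 of the 2 values shown sit. Going by the values given here, the one measured step, a step that the two limits leave unreadable from compound 1 to compound 2, offers no size to carry forward.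

Compound 3 `C#CC[C@]1(O)[C@@H](CO)OC(n2ccc(N)nc2=O)[C@@H]1O` differs from compound 2 as follows: the two compounds have the same atoms and bonds; at least one stereo element is drawn with a configuration in one of them and without one in the other: 2 of 4 stereo elements differ; a stereocentre at a saturated ring carbon is drawn S in compound 2 and R in compound 3; a stereocentre at a saturated ring carbon is drawn R in compound 2 and without a configuration in compound 3. Among the compounds with values here, no measured step bears directly on this stereochemical change, so its size cannot be read from the data. With only the limit of compound 2 at > 350000 nM to go on, no step beyond the scatter is expected in this assay, although a gain in inhibition cannot be excluded. The expected change is an at least 1.1-fold lower number from compound 2 to compound 3 (0.06 log units; that floor lies within the scatter). Compound 3 is estimated at 300000 nM, with an expected range from 60000 nM to 350000 nM.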

Compound 3, half-maximal inhibitory concentration: > 350000 nM
Compound 3: no number, only a limit (the forecaster's own chance of this, stated with the estimate: 80%); middle value at least 1.1-fold (0.06 log units) from the limit.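

In this assay compound 3 gives > 350000 nM, a limit, so no step can be read between compound 2 and compound 3: the limit of > 350000 nM in this assay, at which 3 of the 3 values shown sit. The compounds shown leave open whether the configuration at these saturated ring carbons changes inhibition at all.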